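The source may report more compounds than this note shows. Statements on the series, on what has been measured and on what is new or still open speak of the compounds shown alone.

Of the compounds shown here, two have been measured in a functional assay on PC-3 cells (Homo sapiens) for inhibition, read by MTT assay, with a stated time of 48 h; a lower number here means a stronger inhibitor, a higher number a weaker inhibitor. Compound 1 `CC(C)C(=O)N(CC(=O)NCCN)c1ccc([N+](=O)[O-])c(C(F)(F)F)c1` gives 20100 nM in this assay. Compound 2 `CCCCCCCCCCCCOc1cc(OCCCCCCCCCCCC)cc(C(=O)OC)c1` sits at the limit of > 1000000 nM in this assay, at which 1 of the 2 values shown sits, so compound 2 gives > 1000000 nM, which is a limit of the assay and not a number. Compound 3 `CCCCCCCCCCCCOc1cc(OCCCCCCCCCCCC)cc(C(=O)NCCN)c1` has not been measured yet; it differs from compound 2 by (2-aminoethyl)amino in place of methoxy on a carbonyl carbon. For the measured compounds named here, no measured step sets a size for this change. Compound 3 is expected to move from compound 2 by an at least 2.5-fold lower number from compound 2 to compound 3 (0.39 log units; beyond the scatter), a step that may not exceed the scatter. Compound 3 is estimated at 400000 nM, within 60000 nM to 1000000 nM.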

Compound 3, half-maximal inhibitory concentration: > 1000000 nM
Compound 3: only a limit was reported (the forecaster's own chance of this, stated with the estimate: 45%); at least 2.5-fold (0.39 log units) between middle value and limit.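

No step from compound 2 to compound 3 can be read, because both compounds stand at a limit and not at a number: the limit of > 1000000 nM in this assay, at which 2 of the 3 values shown sit.

The compounds shown leave open whether (2-aminoethyl)amino in place of methoxy on a carbonyl carbon changes the value at all, and in which direction.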